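From Ethoxycarbonyl to Methoxycarbonyl

The source may hold more compounds than are shown below. What is called first, only, known or untested is meant among the compounds shown, and "the series" means these compounds.

Among the compounds with values here, in a functional assay on HCT-116 cells (Homo sapiens) for inhibition, read by MTT assay, with a stated time of 72 h (on this read-out lower numbers stand for stronger inhibition of growth and higher numbers for weaker inhibition of growth), compound 1 (`NNC(=O)COc1ccncc1-c1ccc2ccccc2c1`) has the entry "not determined" (no result reported) and compound 2 (`CCOC(=O)/C=C/c1ccncc1-c1ccc2ccccc2c1`) gives 910 nM as the only number, so compound 2 has no measured neighbour to be ranked against. Compound 3 (`COC(=O)/C=C/c1ccncc1-c1ccc2ccccc2c1`) differs in one place: hydrogen in place of methyl on a saturated chain carbon bound to an oxygen next to a carbonyl group describes hydrogen in place of methyl on a saturated chain carbon bound to an oxygen next to a carbonyl group, turning ethoxycarbonyl into methoxycarbonyl. Within the data shown here, no measured step is available as a guide. The expected step of a 1.1-fold higher number from compound 2 to compound 3 (0.04 log units; within the scatter) stays within the usual scatter, in neither direction. The estimated value for compound 3 is 1000 nM with a range of 400 nM to 2500 nM on this measure.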

Compound 3, concentration for 50% growth inhibition: 350 nM
Compound 3: the middle estimate sits 2.9-fold (0.46 log units) above what was measured; measured number outside the range, below it.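

In this assay, within the data shown here, going from ethoxycarbonyl to methoxycarbonyl gives a 2.6-fold lower number from compound 2 to compound 3 (0.41 log units; beyond the scatter), the first measured step. A change as small as one methyl, on a saturated chain carbon bound to an oxygen next to a carbonyl group, therefore moves growth inhibition modestly but beyond the usual scatter. Nothing measured here explains why the methoxycarbonyl compound gives the lower number.

This is a single pair, so it sets no trend along the chain. The compounds shown leave open how a longer chain such as propoxycarbonyl, or a carboxylic acid in place of methoxycarbonyl, would read out.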